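This account rests on a few compounds, and the source may have more. Where it says the series, first, only, none or still open, it means among the compounds named here.

Measured compounds in a functional assay on HT-29 cells (Homo sapiens) for antiproliferative activity, read by sulforhodamine B assay, with a stated time of 48 h; on this read-out higher numbers stand for weaker inhibition and lower numbers for stronger inhibition:
compound 1 `CCCCCC(=O)Nc1ccc(S(=O)(=O)Oc2ccccc2I)cc1` — 13000 nM
compound 2 `CC(C)(C)C(=O)Nc1ccc(S(=O)(=O)Oc2ccccc2I)cc1` — 9500 nM
compound 3 `CC(C)c1ccccc1OS(=O)(=O)c1ccc(NC(=O)NCC2CCCC2)cc1` — 6800 nM

Compound 3 has the lowest of the three numbers in this assay, but its distance to compound 2 and to compound 1 is within the scatter, so no order among the three can be read. Going by the values given here, the one single-place step on record, a 1.4-fold lower number from compound 1 to compound 2 (0.14 log units; within the scatter), changes the acyl group on the amide nitrogen and stays within the scatter.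

Compound 4 `O=C(NCC1CCCC1)Nc1ccc(S(=O)(=O)Oc2ccccc2I)cc1` is not yet measured. It differs from compound 3 in one place: iodo in place of isopropyl on an aromatic carbon, that is, 2-isopropylphenyl to 2-iodophenyl on the sulfonate ester side. Among the compounds with values here, no measured pair isolates this exchange: compound 1 and compound 2 carry the iodo group but differ from compound 3 in the amide against urea part as well, so their values show only that the iodo-bearing compounds sit within the scatter of compound 3. The step recorded between compound 1 and compound 2 does not bear on the aryl substituent.

With nothing pointing either way, compound 4 is expected to stay close to compound 3, a step of a 1.3-fold higher number from compound 3 to compound 4 (0.10 log units; within the scatter) in this assay. The estimate for compound 4 is 8500 nM, with a range from 3000 nM to 25000 nM.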

Compound 4, half-maximal inhibitory concentration: 7600 nM
Compound 4: the middle estimate sits 1.1-fold (0.05 log units) above what was measured; measured number inside the range.
By their numbers in this assay, from the lowest: compounds 3, 4, 2 and 1 (each within the scatter of the next).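

In this assay, the exchange of 2-isopropylphenyl for 2-iodophenyl now has a matched pair: a 1.1-fold higher number from compound 3 to compound 4 (0.05 log units; within the scatter) shows that, on this aromatic carbon ortho to a large group, iodo and isopropyl are not separated, although one heavy atom stands in place of three. With the 2-iodophenyl side held fixed, the carbonyl side can also be read directly, and neither a 1.3-fold lower number from compound 2 to compound 4 (0.10 log units; within the scatter) nor a 1.7-fold lower number from compound 1 to compound 4 (0.23 log units; within the scatter) separates (cyclopentylmethyl)amino from tert-butyl or pentyl in this read-out. Nothing measured here offers a reason for these results.

As far as these compounds go, since every step stays within the scatter, it remains open whether any change at either place moves the number beyond it, for example a methoxy group, a carboxylic acid or an unsubstituted phenyl on the sulfonate ester side. From the compounds shown here alone, on the carbonyl side, it also remains open whether an amine on the chain or a longer chain in place of the cyclopentyl ring would separate from the groups compared so far.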